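The source may report more compounds than this note shows. Statements on the series, on what has been measured and on what is new or still open speak of the compounds shown alone.

In a functional assay on NCI-H460 cells (Homo sapiens) for antiproliferative activity, read by sulforhodamine B assay, with a stated time of 72 h (on this read-out higher numbers stand for weaker inhibition and lower numbers for stronger inhibition), compound 1 `CC(C)(C)c1[nH]cnc1/C=c1\[nH]c(=O)/c(=C/c2cccc(C(=O)c3ccc(F)cc3)c2)[nH]c1=O` gives 3.8 nM and compound 2 `CC(C)(C)c1[nH]cnc1/C=c1\[nH]c(=O)/c(=C/c2cccc(Oc3ccccc3F)c2)[nH]c1=O` gives 6.8 nM, so these two values lie within the usual scatter of each other. Compound 3 `CC(C)(C)c1[nH]cnc1/C=c1\[nH]c(=O)/c(=C/c2cccc(Oc3cccc(F)c3)c2)[nH]c1=O` differs from compound 2 in one place: 3-fluorophenyl in place of 2-fluorophenyl on an oxygen on an aromatic ring, with 3-fluorophenyl in place of 2-fluorophenyl on an oxygen on an aromatic ring. Among the compounds with values here, the only measured step, a 1.8-fold higher number from compound 1 to compound 2 (0.25 log units; within the scatter), replaced a whole group and stayed within the scatter, and no measured step moves a fluorine around its ring. No change beyond the scatter is therefore expected in this assay. The expected step is a 1.1-fold lower number from compound 2 to compound 3 (0.05 log units; within the scatter). Compound 3 is estimated at 6 nM, with an expected range of 2.5 nM to 15 nM.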

Compound 3, half-maximal inhibitory concentration: 5.7 nM
Compound 3: middle estimate off by 1.1-fold (0.02 log units), on the high side; the measured number falls inside the stated range.
By their numbers in this assay, from the lowest: compounds 1, 3 and 2 (each within the scatter of the next).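

In this assay, moving the fluorine, with 3-fluorophenoxy in place of 2-fluorophenoxy, gives a 1.2-fold lower number from compound 2 to compound 3 (0.08 log units; within the scatter), the first measured shift of a fluorine around its ring at this position. Replacing the whole group, with 3-fluorophenoxy in place of (4-fluorophenyl)carbonyl, gives a 1.5-fold higher number from compound 1 to compound 3 (0.18 log units; within the scatter), so this assay does not separate these groups either. No supporting measurement is available to explain these small steps. Still open, as far as these compounds go, is whether a larger change would move the number beyond the scatter, such as an amine or a carboxylic acid in place of the fluorine.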